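A few compounds are considered here, and "the series" means these few. Any claim that something is new, unique, unknown or untested is made for them only; others in the source may bear on it.

Series notes. Compound 1 `CCC(CC)Nc1ncnc2c1ncn2C1O[C@H](C(=O)NC)[C@@H](O)[C@H]1O` holds the lowest of the two numbers obtained so far in an assay with adenosine receptor A1 (Rattus norvegicus) as the target (on this read-out higher numbers stand for weaker inhibition and lower numbers for stronger inhibition), where compound 1 gives 20 nM. Compound 2 `CCNC(=O)[C@H]1OC(n2cnc3c(NC)ncnc32)[C@H](O)[C@@H]1O` gives 120 nM in this assay, a gap beyond the scatter. Compound 3 `C=CCNC(=O)[C@H]1OC(n2cnc3c(NC(CC)CC)ncnc32)[C@H](O)[C@@H]1O` has not been measured. It differs from compound 1 by vinyl in place of hydrogen on a saturated chain carbon bound to an amide-type nitrogen, read one bond further out as methylcarbamoyl to allylcarbamoyl. Among the compounds with values here, no measured pair isolates this change, so only a small step is expected, if anything towards a slightly higher number, and it may stay within the scatter: a 1.5-fold higher number from compound 1 to compound 3 (0.18 log units; within the scatter). For compound 3 the estimated value is 30 nM, between 10 nM and 90 nM.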

Compound 3, half-maximal inhibitory concentration: 17 nM
Compound 3: middle estimate off by 1.8-fold (0.25 log units), on the high side, within the range that was stated.
By their numbers in this assay, from the lowest: compounds 3 and 1 (each within the scatter of the next); then compound 2.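

Methylcarbamoyl to allylcarbamoyl is the first change isolated in this series, and it gives a 1.2-fold lower number from compound 1 to compound 3 (0.07 log units; within the scatter) in this assay. The position therefore accepts vinyl in place of hydrogen on a saturated chain carbon bound to an amide-type nitrogen, with the two numbers remaining within the scatter of each other. No available evidence bears on this outcome. From the compounds shown here alone, whether a benzyl group, a longer chain or a terminal amine in the same place would also stay within the scatter of compound 1 remains open.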